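The source may report more compounds than this note shows. Statements on the series, on what has been measured and on what is new or still open speak of the compounds shown alone.

The measured compounds:
Compound 1 `CC(C)C[C@@H]1NC(=O)[C@H](CCCCN)NC1=O` gives 96% in a functional assay, tested at 2.5 mM; on this read-out higher numbers stand for more inhibition at the one concentration tested (going by the name of the read-out) and lower numbers for less inhibition.
Compound 2 `CSCC[C@@H]1NC(=O)[C@H](CC(C)C)NC1=O` gives 79%.
Compound 3 `CC(C)C[C@@H]1NC(=O)[C@H](Cc2cnc[nH]2)NC1=O` gives 83.9%.

In this assay compound 3 stands second highest of the three: compound 1 is higher, as a number 12.1 percentage points lower from compound 1 to compound 3 (beyond the scatter) shows, while compound 2 and compound 3 lie within the scatter of each other, as a number 4.9 percentage points higher from compound 2 to compound 3 (within the scatter) shows. Compound 4 `CC(C)C[C@@H]1NC(=O)[C@H](CS)NC1=O` has not yet been measured. It differs from compound 3 by sulfanyl in place of 1H-imidazol-5-yl on a saturated chain carbon bound to a saturated ring carbon. Two measured steps changed this same place: a number 12.1 percentage points lower from compound 1 to compound 3 (beyond the scatter) and a number 4.9 percentage points higher from compound 2 to compound 3 (within the scatter). The second, which exchanged (methylsulfanyl)methyl for 1H-imidazol-5-yl, stayed within the scatter; the step of a number 17 percentage points lower from compound 1 to compound 2 (beyond the scatter) changed another place. A return to a sulfur-bearing side group is therefore expected to land near compound 2, so a number 4.9 percentage points lower from compound 3 to compound 4 (within the scatter) is expected to stay within the scatter. The estimate for compound 4 is 79%, ranging from 62% to 92%.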

Compound 4, a percentage reported as inhibition, at one concentration (the size of the read-out at that concentration, not a potency): 88.9%
The estimate for compound 4 lay 9.9 percentage points below the measured number, and the stated range covers the measured number.
By their numbers in this assay, from the lowest: compounds 2, 3, 4 and 1 (each within the scatter of the next, the first and the last beyond it).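

Sulfanyl, a single heavy atom, can replace the five-atom 1H-imidazol-5-yl at this place in this assay with the numbers staying within the scatter (a number 5 percentage points higher from compound 3 to compound 4 (within the scatter)). Compound 4 also lies within the scatter of the compounds bearing (methylsulfanyl)methyl (a number 9.9 percentage points higher from compound 2 to compound 4 (within the scatter)) and 3-aminopropyl (a number 7.1 percentage points lower from compound 1 to compound 4 (within the scatter)), so side groups that differ this widely in size need not separate the numbers. Nothing available explains this result.

As far as these compounds go, how a carboxylic acid or a phenyl ring would read at this place remains open. A single concentration also leaves the potency of all these compounds unknown.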